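The source may hold more compounds than are shown below. What is called first, only, known or untested is meant among the compounds shown, and "the series" means these compounds.

In a functional assay on A549 cells (Homo sapiens) for antiproliferative activity, read by MTT assay, with a stated time of 48 h (a lower number here means a stronger inhibitor, a higher number a weaker inhibitor), the measured compounds read as follows
- compound 1 `C=C(c1ccc2c(c1)C=CC(C)(C)O2)c1ccc(OC)cc1NC(=O)CNC` gives 200 nM
- compound 2 `C=C(c1cc(OC)c(OC)c(OC)c1)c1ccc(OC)c(O)c1NC(C)=O` gives 80 nM
- compound 3 `C=C(c1cc(OC)c(OC)c(OC)c1)c1ccc(OC)c(O)c1NC(=O)COC` gives 190 nM

Compound 3 lies within the scatter of compound 1, while compound 2 carries a lower number. The next compound, compound 4 `C=C(c1cc(OC)c(OC)c(OC)c1)c1ccc(OC)c(O)c1NC(=O)COCC`, differs from compound 3 by one change, (methyl in place of hydrogen on a saturated chain carbon bound to an oxygen on a saturated carbon), so that methoxy becomes ethoxy. Going by the values given here, no measured pair tests this change directly. Among the compounds with values here, the nearest evidence is the one measured step, which put methoxy in place of hydrogen on a saturated chain carbon bound to a carbonyl carbon, and it was modest in size, a 2.4-fold higher number from compound 2 to compound 3 (0.38 log units; beyond the scatter). Compound 4 extends that same methoxy, yet a single step sets no pattern. A small further rise in this assay is therefore expected, possibly none beyond the scatter. The expected change is a 1.3-fold higher number from compound 3 to compound 4 (0.10 log units; within the scatter). Compound 4 is estimated at 240 nM, with an expected range from 100 nM to 550 nM.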

Compound 4, half-maximal inhibitory concentration: 880 nM
Estimate against measurement, compound 4: 3.7-fold (0.56 log units) below; the whole stated range lies below it.
By their numbers in this assay, from the lowest: compound 2; then compounds 3 and 1 (each within the scatter of the next); then compound 4.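

In (this assay), the change from methoxy to ethoxy is not a silent extension: the single added methyl, on a saturated chain carbon bound to an oxygen on a saturated carbon, gives (a 4.6-fold higher number from compound 3 to compound 4 (0.67 log units; beyond the scatter)). Going by these compounds alone, this is a second rise in the same direction as the first step on this chain (a 2.4-fold higher number from compound 2 to compound 3 (0.38 log units; beyond the scatter)), so compound 3 no longer stands alone as evidence that this position responds to substitution. Taken as a whole, replacing hydrogen with ethoxy on the saturated chain carbon bound to a carbonyl carbon gives a large change (an 11-fold higher number from compound 2 to compound 4 (1.04 log units; beyond the scatter)), and among compounds 2, 3 and 4 none goes against this rise.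

As far as these compounds go, whether a longer chain such as propoxy continues the rise, or a hydroxyl or a carboxylic acid at this place behaves differently, remains open. The data shown offer nothing that bears on why the number rises.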